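Trifluoromethyl in place of chloro on compound 2

The source may hold more compounds than are shown below. What is called first, only, known or untested is meant among the compounds shown, and "the series" means these compounds.

- Compound 1 `CCN(c1cccc(-n2ccnc2)c1)c1ccc(C#N)c(C(F)(F)F)c1` gives 19000 nM
- Compound 2 `CCN(c1ccc(C#N)c(Cl)c1)c1cc(-n2ccnc2)ccc1C` gives > 30000 nM

Both compounds were tested in a functional assay on CWR22R cells (Homo sapiens) for antiproliferative activity, read by CCK-8 assay, with a stated time of 6 days; a lower number here means a stronger inhibitor, a higher number a weaker inhibitor. For compound 2 the assay reports a limit and not a number (the limit of > 30000 nM in this assay, at which 1 of the 2 values shown sits). Compound 3 `CCN(c1ccc(C#N)c(C(F)(F)F)c1)c1cc(-n2ccnc2)ccc1C` differs from compound 2 by trifluoromethyl in place of chloro on an aromatic carbon, ortho to a cyano group. Compound 1 also carries trifluoromethyl and gives 19000 nM, so only a modest gain is expected in this assay. The expected change is an at least 2.0-fold lower number from compound 2 to compound 3 (0.30 log units; that floor lies within the scatter), toward stronger inhibition. For compound 3 the estimated value is 15000 nM, with an expected range of 4000 nM to 30000 nM.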

Compound 3, half-maximal inhibitory concentration: 16300 nM
Estimate against measurement, compound 3: 1.1-fold (0.04 log units) below; the range from low to high includes it.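

In this assay, trifluoromethyl in place of chloro on an aromatic carbon, ortho to a cyano group, gives an at least 1.8-fold lower number from compound 2 to compound 3 (0.26 log units; that floor lies within the scatter). The value of compound 2 is a limit and not a number, so this step has only a floor: the limit of > 30000 nM in this assay, at which 1 of the 3 values shown sits.

Methyl in place of hydrogen on an aromatic carbon gives a 1.2-fold lower number from compound 1 to compound 3 (0.07 log units; within the scatter), so these two numbers cannot be told apart.

Going by these compounds, what stays open is how large the step from chloro to trifluoromethyl truly is. On these data alone, how a bromo or methoxy group in that place would read also stays open.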